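Removing the chlorines from compound 1: working notes

The source may report more compounds than this note shows. Statements on the series, on what has been measured and on what is new or still open speak of the compounds shown alone.

Measured in a functional assay on A549 cells (Homo sapiens) for antiproliferative activity, read by MTT assay, with a stated time of 72 h; on this read-out higher numbers stand for weaker inhibition and lower numbers for stronger inhibition:
- compound 1 `COc1cc(-c2ncnn2-c2ccc(Cl)cc2Cl)cc(OC)c1OC`: > 10000 nM
- compound 2 `COc1cc(-n2ncnc2-c2ccc(Cl)c(Cl)c2)cc(OC)c1OC`: > 10000 nM
- compound 3 `CCOc1cccc(-c2ncnn2-c2cc(OC)c(OC)c(OC)c2)c1`: > 10000 nM

All three entries are limits and not numbers, so the series has no measured potency yet and no order among its members. The evidence so far comes down to one observation: the limit of > 10000 nM in this assay, at which 3 of the 3 values shown sit.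

Compound 1 therefore stands at a limit, and this assay gives no number from which a step could be counted. Within the data shown here, no step between measured compounds is available as a guide either.

The next compound is compound 4 `COc1cc(-c2ncnn2-c2ccccc2)cc(OC)c1OC`, which has phenyl in place of 2,4-dichlorophenyl on an aromatic nitrogen. The change sits on an aromatic nitrogen of a five-membered aromatic ring with 3 nitrogen, and the rest of compound 1 stays as it is.

No step beyond the scatter is expected in this assay, and no direction can be assigned. This expectation rests on compound 1 with its limit of > 10000 nM. The most likely result for compound 4 is another limit. The estimated step is a step that the limit leaves unreadable from compound 1 to compound 4. For compound 4 the expected value is 12000 nM, with an estimated range from 3000 nM to 40000 nM.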

Compound 4, half-maximal inhibitory concentration: > 10000 nM
Compound 4: no number, only a limit (the forecaster's own chance of this, stated with the estimate: 70%); the middle value does not contradict the limit.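

Compound 4 gives > 10000 nM, which is a limit and not a number. Compound 1 also stands at a limit, so no step can be read for phenyl in place of 2,4-dichlorophenyl. The compounds shown leave open whether the chlorines matter at all and which change would give a readable potency: the limit of > 10000 nM in this assay, at which 4 of the 4 values shown sit.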